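Cytotoxicity notes: indolyl to hydroxyphenyl in the ester series

This account rests on a few compounds, and the source may have more. Where it says the series, first, only, none or still open, it means among the compounds named here.

Compound 3 `CCOC(=O)CCCCCOc1cccc(CN(C(=O)c2ccc(-c3ccc4cc[nH]c4c3)cc2)C(C)C)c1` reaches in an ADME assay on BJ cells (Homo sapiens) for cytotoxicity, read by CellTiter-Glo and resazurin assay, with a stated time of 72 h (a lower number here means that less compound is needed, a higher number that more compound is needed for the effect), only the limit > 26000 nM. Compound 1 `CCOC(=O)CCCCCOc1cccc(CN(C(=O)c2ccc(-c3ccco3)cc2)C(C)C)c1` likewise stops at the limit > 26000 nM. Compound 2 `CCOC(=O)CCCCCOc1cccc(CN(C(=O)c2ccc(-c3cccc(-c4nnc(C)o4)c3)cc2)C(C)C)c1` also stops at the limit > 26000 nM. Hence a step that the two limits leave unreadable from compound 1 to compound 2, a step that the two limits leave unreadable from compound 1 to compound 3 and a step that the two limits leave unreadable from compound 2 to compound 3 carry no readable size, because all three values sit at the limit of > 26000 nM in this assay, at which 3 of the 3 values shown sit. Compound 4 `CCOC(=O)CCCCCOc1cccc(CN(C(=O)c2ccc(-c3cccc(O)c3)cc2)C(C)C)c1` differs from compound 3 by 3-hydroxyphenyl in place of 1H-indol-6-yl on an aromatic carbon. Among the compounds with values here, no measured step reads on this change; the only evidence is the limit of > 26000 nM in this assay, at which 3 of the 3 values shown sit. Compound 4 is therefore expected to remain beyond the reach of this assay, with an estimated 40000 nM and a range from 15000 nM to 120000 nM. The expected step that the limit leaves unreadable from compound 3 to compound 4 is nominal only.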

Compound 4, half-maximal effective concentration: > 26000 nM
Compound 4: a limit, no number; the forecaster's own chance of this, stated with the estimate: 85%; the middle value does not contradict the limit.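

Compound 4 stops at a limit, as do compound 1, compound 2 and compound 3, so none of the steps to compound 4 can be read: the limit of > 26000 nM in this assay, at which 4 of the 4 values shown sit.

As far as these compounds go, whether the groups exchanged on this aromatic carbon differ at all in this assay stays open, as does the concentration at which any of the four compounds takes effect.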